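The source may report more compounds than this note shows. Statements on the series, on what has been measured and on what is new or still open speak of the compounds shown alone.

Of the compounds shown here, two built on one shared core have been tested in an ADME assay on MDBK cells (Bos taurus) for cytotoxicity; on this read-out higher numbers stand for lower toxicity in this test and lower numbers for higher toxicity in this test. Compound 1 `Clc1ccccc1Cn1ccc2nc(-c3ccccc3)nc-2c1` returned only a limit of the assay rather than a number, namely > 100000 nM in this assay. Compound 2 `CC(c1ccccc1)n1ccc2nc(-c3ccccc3)nc-2c1` likewise returned a limit and no number, with > 100000 nM in this assay. For the measured compounds named here, compound 1 therefore stands at the limit of > 100000 nM in this assay, at which 2 of the 2 values shown sit, so its result cannot be ranked against the other, and no step between measured compounds differing in a single place is available to show how large a change of this kind usually is.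

Compound 3 `CC(C)=CCn1ccc2nc(-c3ccccc3)nc-2c1` is the compound awaiting measurement in this assay. It differs from compound 1 in one place (2-methylprop-1-en-1-yl in place of 2-chlorophenyl on a saturated chain carbon bound to an aromatic nitrogen). Given that compound 1 sits at the limit of > 100000 nM in this assay, at which 2 of the 2 values shown sit, the step from compound 1 to compound 3 is expected to be none beyond the scatter, and a number no higher from compound 1 to compound 3 (the limit leaves the size open) states that expectation. For compound 3 the estimated result in this assay is 100000 nM, with an expected range from 40000 nM to 300000 nM, most likely reported once more as a limit rather than as a number.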

Compound 3, half-maximal cytotoxic concentration: > 100000 nM
Compound 3 was reported as a limit; the forecaster's own chance of this, stated with the estimate: 80%; the middle value lies on the limit itself.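

In this assay compound 3 gives > 100000 nM, which is a limit and not a number. No step from compound 1 to compound 3 can be read, because both results are limits: the limit of > 100000 nM in this assay, at which 3 of the 3 values shown sit.

The compounds shown leave open how these three truly compare, and whether any group at this place would give a measurable number in this assay.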